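Halogenated Phenyl Swap on the Ring Amine, Untested

The compounds below may be only part of what the source reports. "The series", "measured", "known", "first", "only" and "open" are said of these compounds alone.

In an assay on HEK293 cells for inhibition of Voltage-dependent T-type calcium channel subunit alpha-1G (Homo sapiens), read by fluorescence, tested at 10 uM (on this read-out higher numbers stand for more inhibition at the one concentration tested (going by the name of the read-out) and lower numbers for less inhibition), three compounds share one core and differ only in the group attached to an amine nitrogen in a ring. Compound 1 `CCCc1nc(-c2ccccc2)c(CNCCN2CCN(c3ccccc3OC)CC2)o1` gives 39.7%, compound 3 `CCCc1nc(-c2ccccc2)c(CNCCN2CCN(c3ccccn3)CC2)o1` gives 48.1%, and compound 2 `CCCc1nc(-c2ccccc2)c(CNCCCN2CCN(c3cccc(F)c3)CC2)o1` gives 68.9%, the highest of the three; the gaps from compound 2 to the other two lie beyond the scatter. Among the measured compounds shown here, the one step measured so far, a number 8.4 percentage points higher from compound 1 to compound 3 (within the scatter), exchanges one aromatic group for another at that position. Compound 4 `CCCc1nc(-c2ccccc2)c(CNCCCN2CCN(c3ccc(Cl)cc3)CC2)o1` has not been measured; (4-chlorophenyl in place of 3-fluorophenyl on an amine nitrogen in a ring). For the measured compounds named here, no measured step swaps one halogen-bearing phenyl for another, so the expectation rests on the small size of that single step, and a change within the scatter is expected, a number 3.9 percentage points lower from compound 2 to compound 4 (within the scatter). Compound 4 is estimated at 65%, within 45% to 85%.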

Compound 4, a percentage reported as inhibition, at one concentration (the size of the read-out at that concentration, not a potency): 63.3%
For compound 4 the middle estimate is 1.7 percentage points above the measured one, within the range that was stated.
By their numbers in this assay, from the lowest: compounds 1 and 3 (each within the scatter of the next); then compounds 4 and 2 (each within the scatter of the next).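

The step from 3-fluorophenyl to 4-chlorophenyl changes both the halogen and its place on the phenyl ring, yet in this assay it amounts to a number 5.6 percentage points lower from compound 2 to compound 4 (within the scatter) on the ring amine nitrogen. Among the compounds shown here, this is the first measured swap between two halogen-bearing phenyl groups here, and the two compounds cannot be told apart. No supporting data bear on why the values stay so close.

From the compounds shown here alone, because both the halogen and its place changed together, their separate contributions remain open. A 3-chlorophenyl or 4-fluorophenyl group would separate them, and an unsubstituted phenyl group would show whether a halogen matters at all.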